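Rat microsomal stability notes: carboxyphenoxy linker change in compound 4

The source may hold more compounds than are shown below. What is called first, only, known or untested is meant among the compounds shown, and "the series" means these compounds.

The working set here is three measured compounds and one still to be run. Compound 1 `CCC(=O)c1ccc(OCCCCOc2ccc(F)c(C(=O)O)c2)c(C)c1O` gives 35% in an ADME assay (liver) for metabolic stability, with Liver microsome (Rattus norvegicus) as the target, read by LC-MS, using microsomes and NADPH, with stated times of 5 min and 60 min, tested at 4 uM; on this read-out lower numbers stand for a less stable compound and higher numbers for a more stable compound. Compound 2 `Cc1c(OCCCCOCOc2ccc(C(=O)O)cc2)ccc(C(=O)CC2CCCC2)c1O` gives 31% in this assay, and compound 3 `Cc1c(OCCCCOc2ccccc2C(=O)O)ccc(C(=O)CC(C)C)c1C` gives 9%.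

Among these three numbers compound 2 stands second highest. Its nearest neighbour is compound 1, whose number lies higher by an amount within the usual scatter, so the two cannot be ranked against each other. Compound 3 lies furthest away, its number being lower by an amount beyond the scatter, so compound 3 is the less stable of that pair.

Compound 4 `Cc1c(OCCCCOc2cccc(C(=O)O)c2)ccc(C(=O)CC2CCCC2)c1O` has not been measured. It differs from compound 2 in one place: 3-carboxyphenyl in place of (4-carboxyphenoxy)methyl on an oxygen on a saturated carbon. Among the measured compounds shown here, no step between two measured compounds isolates this change, so no measured step can be borrowed for it. Compound 1 and compound 2, which carry different linkers between the shared core and the carboxyphenyl group, sit within the scatter of each other, so the expectation for this change is a step of no size beyond the scatter, estimated as a number 2 percentage points higher from compound 2 to compound 4 (within the scatter). On that basis compound 4 is expected to give about 33% in this assay, with a range from 15% to 55%.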

Compound 4, percent of the compound remaining: 55%
For compound 4 the middle estimate is 22 percentage points below the measured one; measured number inside the range.
By their numbers in this assay, from the lowest: compound 3; then compounds 2 and 1 (each within the scatter of the next); then compound 4.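

In this assay the group on this oxygen turns out to matter: 3-carboxyphenyl in place of (4-carboxyphenoxy)methyl gives a number 24 percentage points higher from compound 2 to compound 4 (beyond the scatter) with the rest of the molecule unchanged. Among the compounds shown here, this is the first reading of a single change, since the earlier compounds differ from one another in more than one place and could not separate the effect of this position from the rest. The swap is still a bundled one, as the group that leaves has 11 heavy atoms and 2 hydrogen-bond acceptors and the group that enters has 9 heavy atoms and 1 hydrogen-bond acceptor, so the step belongs to the replacement as a whole and not to any one part of it.

The compounds shown do not separate the shorter attachment from the altered place of the carboxylic acid on the ring, and they leave open whether a tetrazole in place of that carboxylic acid would hold the number on this 3-substituted phenyl group. Nothing available gives a reason for the step.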